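This account rests on a few compounds, and the source may have more. Where it says the series, first, only, none or still open, it means among the compounds named here.

Measured in a functional assay on HeLa cells (Homo sapiens) for antiproliferative activity, read by MTT assay, with a stated time of 72 h; a higher number here means a weaker inhibitor, a lower number a stronger inhibitor:
- Compound 1 `COc1cccc(Nc2nc3c(c(Oc4cccc(NC(=O)/C=C/C(C)C)c4)n2)CSCC3)c1`: > 50000 nM, a limit of the assay
- Compound 2 `C=CC(=O)Nc1cccc(Oc2nc(Nc3ccc(OC)nc3)nc3c2CSCC3)c1`: 26300 nM
- Compound 3 `C/C=C/C(=O)Nc1cccc(Oc2nc(Nc3ccc(OC)nc3)nc3c2CSCC3)c1`: 16500 nM

Compound 3 and compound 2 lie within the usual scatter of each other, so neither can be ranked ahead. Compound 4 `COc1ccc(Nc2nc3c(c(Oc4cccc(NC(=O)/C=C/C(C)C)c4)n2)CSCC3)cn1` has isopropyl in place of methyl on a double-bonded chain carbon bound to a double-bonded chain carbon. This turns prop-1-en-1-yl into 3-methylbut-1-en-1-yl.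

Within the data shown here, one measured step bears on this chain: a 1.6-fold lower number from compound 2 to compound 3 (0.20 log units; within the scatter). It is small and gives no clear direction. Compound 1 also carries 3-methylbut-1-en-1-yl, and its > 50000 nM is a limit. Taken together, these suggest a modest move towards higher numbers in this assay. The expected change is a 1.7-fold higher number from compound 3 to compound 4 (0.23 log units; within the scatter). For compound 4 the estimated value is 28000 nM, with an expected range of 12000 nM to 50000 nM.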

Compound 4, half-maximal inhibitory concentration: 27800 nM
Compound 4: the middle estimate sits 1.0-fold (0.00 log units) above what was measured; the range from low to high includes it.
By their numbers in this assay, from the lowest: compounds 3, 2 and 4 (each within the scatter of the next). At a limit, above all of these: compound 1.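

In this assay, 3-methylbut-1-en-1-yl in place of prop-1-en-1-yl gives a 1.7-fold higher number from compound 3 to compound 4 (0.23 log units; within the scatter), and in place of vinyl it gives a 1.1-fold higher number from compound 2 to compound 4 (0.02 log units; within the scatter), so none of the three chain ends shown on the carbonyl stands clear of the others. 6-Methoxypyridin-3-yl in place of 3-methoxyphenyl gives an at least 1.7-fold lower number from compound 1 to compound 4 (0.25 log units; that floor lies within the scatter), so these two groups cannot be ranked. The value of compound 1 is a limit: the limit of > 50000 nM in this assay, at which 1 of the 4 values shown sits.

The compounds shown do not tell whether a dimethylamino group on this chain, or a longer chain, would move the number beyond the scatter.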